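Extending a Weakly Cytotoxic Series From Compound 3 to Compound 4

The compounds below may be only part of what the source reports. "The series", "measured", "known", "first", "only" and "open" are said of these compounds alone.

Of the compounds shown here, three sharing one core have been measured in a functional assay on HCT-116 cells (Homo sapiens) for cytotoxicity, read by MTT assay, with a stated time of 72 h; on this read-out lower numbers stand for stronger inhibition and higher numbers for weaker inhibition. Compound 1 `[N-]=[N+]=NCc1nnc(-c2cc(S(N)(=O)=O)c(SCc3ccccc3)cc2Cl)o1` gives 100000 nM in this assay. Compound 2 `CC(C)(O)c1cn(Cc2nnc(-c3cc(S(N)(=O)=O)c(SCc4ccccc4)cc3Cl)o2)nn1` gives 82000 nM, and compound 3 `NS(=O)(=O)c1cc(-c2nnc(CNS(=O)(=O)c3ccc(Cl)cc3)o2)c(Cl)cc1SCc1ccccc1` gives 32000 nM. Among these three numbers compound 3 stands lowest: the step of a 3.1-fold lower number from compound 1 to compound 3 (0.49 log units; beyond the scatter) and the step of a 2.6-fold lower number from compound 2 to compound 3 (0.41 log units; beyond the scatter) both lie beyond the scatter, whereas the step of a 1.2-fold lower number from compound 1 to compound 2 (0.09 log units; within the scatter) does not.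

Compound 4 `NS(=O)(=O)c1cc(-c2nnc(/C=C/c3ccc(Cl)cc3)o2)c(Cl)cc1SCc1ccccc1` differs from compound 3 in one place: 2-(4-chlorophenyl)ethenyl in place of (((4-chlorophenyl)sulfonyl)amino)methyl on an aromatic carbon. Among the compounds with values here, none of the measured steps concerns this kind of change. All three of them exchange the group on the saturated chain carbon while keeping that carbon in place, whereas here the whole (((4-chlorophenyl)sulfonyl)amino)methyl group leaves and 2-(4-chlorophenyl)ethenyl enters. What the measured steps do show is that variation at this end of the molecule has shifted the read-out only by modest amounts within a narrow band of weak activity.

Compound 4 is therefore expected to land near compound 3, with the step of a 1.1-fold lower number from compound 3 to compound 4 (0.03 log units; within the scatter) expected to fall within or at most modestly beyond the scatter, in either direction. The estimate for compound 4 in this assay is 30000 nM, with a range from 10000 nM to 90000 nM.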

Compound 4, half-maximal inhibitory concentration: 12000 nM
Estimate against measurement, compound 4: 2.5-fold (0.40 log units) above; measured number inside the range.
By their numbers in this assay, from the lowest: compound 4; then compound 3; then compounds 2 and 1 (each within the scatter of the next).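

In this assay, the whole (((4-chlorophenyl)sulfonyl)amino)methyl group could leave this aromatic carbon, next to the ring oxygen, and 2-(4-chlorophenyl)ethenyl could enter, with the change giving a 2.7-fold lower number from compound 3 to compound 4 (0.43 log units; beyond the scatter) and so moving the number further than the earlier exchanges on the saturated chain carbon had. Set against the other two compounds, the same group gives a 6.8-fold lower number from compound 2 to compound 4 (0.83 log units; beyond the scatter) and an 8.3-fold lower number from compound 1 to compound 4 (0.92 log units; beyond the scatter), which makes compound 4 the lowest of the four, each of its steps lying beyond the scatter, although all of these steps remain modest and the entering group carries no hydrogen-bond donors or acceptors. No measurement at hand accounts for this shift.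

The compounds shown leave open whether the ethenyl double bond matters, since 2-(4-chlorophenyl)ethyl would keep the chlorophenyl ring while removing that bond, and whether the chlorine matters, since 2-phenylethenyl would remove only that atom. They also leave open how an amine or a carboxylic acid on the entering ring would change the number on this read-out.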